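Methoxy Replaces Chloro on the Fused Ring

The source may hold more compounds than are shown below. What is called first, only, known or untested is meant among the compounds shown, and "the series" means these compounds.

Two measured compounds share one core and differ only in a single group on a fused ring. Compound 1 `COc1ccc(C2CC(c3ccc4ccccc4c3)=NN2C2=NC(=O)/C(=C3/C(=O)Nc4ccc(C)cc43)S2)cc1` carries a methyl there; in a functional assay on A549 cells (Homo sapiens) for antiproliferative activity, read by MTT assay, with a stated time of 72 h (on this read-out lower numbers stand for an effect already at smaller amounts and higher numbers for an effect only at larger amounts of compound), compound 1 gives 180 nM. Compound 2 `COc1ccc(C2CC(c3ccc4ccccc4c3)=NN2C2=NC(=O)/C(=C3/C(=O)Nc4ccc(Cl)cc43)S2)cc1` carries a chloro in that place; in this assay compound 2 gives 340 nM. The only measured step, a 1.9-fold higher number from compound 1 to compound 2 (0.28 log units; within the scatter), lies within the scatter, so compound 2 stands at the upper of the two numbers shown without being truly separated from compound 1. Compound 3 `COc1ccc(C2CC(c3ccc4ccccc4c3)=NN2C2=NC(=O)/C(=C3/C(=O)Nc4ccc(OC)cc43)S2)cc1` has not yet been measured. It differs from compound 2 by methoxy in place of chloro on an aromatic carbon. Among the compounds with values here, no measured step involves a methoxy, so only the small methyl-to-chloro step offers guidance, and it points to little movement. Compound 3 is therefore expected to stay near the measured pair, with a step of a 1.4-fold lower number from compound 2 to compound 3 (0.13 log units; within the scatter) in this assay. Compound 3 is estimated at 250 nM, between 100 nM and 650 nM.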

Compound 3, half-maximal effective concentration: 730 nM
Beside the measured number, compound 3's estimate is 2.9-fold (0.47 log units) below it; measured number above the stated range.
By their numbers in this assay, from the lowest: compounds 1 and 2 (each within the scatter of the next); then compound 3.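

Exchanging the chloro for a methoxy gives a 2.1-fold higher number from compound 2 to compound 3 (0.33 log units; beyond the scatter) in this assay. This step lies beyond the usual scatter, which the earlier methyl-to-chloro step did not. Set against the methyl of compound 1, the methoxy gives a 4.1-fold higher number from compound 1 to compound 3 (0.61 log units; beyond the scatter) and thus stands clear of both other compounds, so this position is not indifferent to the group it carries. Nothing shown here explains why the methoxy compound needs a larger amount for the same effect.

Within the data shown here, only three groups appear at this place, so it remains open whether an amine, a carboxylic acid or a longer chain such as ethoxy would give a lower or a higher number. On these data alone, it is also open whether these differences would hold with other groups elsewhere on the shared core.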